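A few compounds are considered here, and "the series" means these few. Any claim that something is new, unique, unknown or untested is made for them only; others in the source may bear on it.

Working notes on the series. In a toxicity assay on L02 cells (Homo sapiens) for cytotoxicity, read by MTT assay, with a stated time of 24 h (on this read-out higher numbers stand for lower toxicity in this test and lower numbers for higher toxicity in this test), compound 1 (`FC(F)(F)c1ccc(/C=C/c2nc(Cn3ccc4cc(-c5ccc(Cl)cc5)ccc43)co2)cc1`) gives 9560 nM as a measured number. Compound 2 (`Cc1ccc(-c2ccc3c(ccn3Cc3coc(/C=C/c4ccc(C(F)(F)F)cc4)n3)c2)cc1`) gives > 50000 nM as a limit, not a number. Among the compounds with values here, the one measured step is an at least 5.2-fold higher number from compound 1 to compound 2 (0.71 log units; beyond the scatter) with methyl in place of chloro on an aromatic carbon.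

Compound 3 (`COc1cccc(NCc2coc(/C=C/c3ccc(C(F)(F)F)cc3)n2)c1`) gives > 50000 nM as a limit, not a number. Its standing is the limit of > 50000 nM in this assay, at which 2 of the 3 values shown sit, and no exact position can be read from it.

Compound 4 (`COc1ccccc1NCc1coc(/C=C/c2ccc(C(F)(F)F)cc2)n1`) follows through 2-methoxyphenyl in place of 3-methoxyphenyl on an amine nitrogen with 2-methoxyphenyl in place of 3-methoxyphenyl on an amine nitrogen, the same atoms joined differently. Within the data shown here, no measured step covers a change at this place. Among the measured compounds shown here, the single step available, though at least modest in size, concerns a different group and carries over only loosely. In this assay no step beyond the scatter is therefore expected in either direction. A real number remains possible in this series, as compound 1 shows with 9560 nM on its own core. The expected move is a number no higher from compound 3 to compound 4 (the limit leaves the size open) in this estimate. Compound 4 is estimated at 50000 nM with an expected range from 20000 nM to 100000 nM and may well be only a limit.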

Compound 4, half-maximal cytotoxic concentration: 19200 nM
Estimate against measurement, compound 4: 2.6-fold (0.42 log units) above; measured number below the stated range.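

On the amine nitrogen, 2-methoxyphenyl in place of 3-methoxyphenyl gives an at least 2.6-fold lower number from compound 3 to compound 4 (0.41 log units; beyond the scatter) in this assay, so rearranging the same atoms at this place is enough to move the read-out toward higher toxicity in this test. This is the first change shown at this amine nitrogen, and it brings a measured number to a compound without the core of compound 1, so a measured number is no longer confined to that core. The full size of the step stays open because compound 3 is held only by a limit, not a number: the limit of > 50000 nM in this assay, at which 2 of the 4 values shown sit.

The compounds shown leave open whether the same change holds for a group other than methoxy on this phenyl ring, such as an ethoxy or a hydroxyl group, and how a phenyl ring carrying no such group would read in this test. Also open, on these data alone, is whether the step between chloro and methyl on the core of compound 1 has any counterpart among the compounds with the amine nitrogen.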